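Compound 3 to compound 4: changing the group on oxygen

This account rests on a few compounds, and the source may have more. Where it says the series, first, only, none or still open, it means among the compounds named here.

Compound 1 `Cc1cn(C2CCN(Cc3cccc(OC4CCCC4)c3)CC2)c(=O)[nH]c1=O` gives 30300 nM in an ADME assay on MRC5 cells (Homo sapiens) for cytotoxicity, read by fluorescence and resazurin assay, with a stated time of 3 days; a higher number here means a weaker inhibitor, a lower number a stronger inhibitor. Compound 2 `Cc1cccc(Oc2cccc(CN3CCC(n4cc(C)c(=O)[nH]c4=O)CC3)c2)c1` reads > 64000 nM, which is a limit. Compound 3 `Cc1cn(C2CCN(Cc3cccc(Oc4cccnc4)c3)CC2)c(=O)[nH]c1=O` reads > 64000 nM, also a limit, and so stands at the limit of > 64000 nM in this assay, at which 2 of the 3 values shown sit. Replacing cyclopentyl gives an at least 2.1-fold higher number from compound 1 to compound 2 (0.32 log units; beyond the scatter) and an at least 2.1-fold higher number from compound 1 to compound 3 (0.32 log units; beyond the scatter). The two aromatic groups leave a step that the two limits leave unreadable from compound 2 to compound 3. Compound 4 `COc1cccc(Oc2cccc(CN3CCC(n4cc(C)c(=O)[nH]c4=O)CC3)c2)c1` carries 3-methoxyphenyl in place of pyridin-3-yl on an oxygen on an aromatic ring. Both aromatic groups measured so far reach the limit, so no step beyond the scatter is expected in this assay, and another limit is likely. The expected step is a number no higher from compound 3 to compound 4 (the limit leaves the size open). For compound 4 the estimate is 64000 nM, with an expected range of 30000 nM to 120000 nM.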

Compound 4, half-maximal inhibitory concentration: 25300 nM
Compound 4: the middle estimate sits 2.5-fold (0.40 log units) above what was measured; measured number below the stated range.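

In this assay, an aromatic group on this oxygen does not by itself reach the limit: 3-methoxyphenyl in place of pyridin-3-yl gives an at least 2.5-fold lower number from compound 3 to compound 4 (0.40 log units; beyond the scatter), and methoxy in place of methyl on an aromatic carbon gives an at least 2.5-fold lower number from compound 2 to compound 4 (0.40 log units; beyond the scatter). The 3-methoxyphenyl and cyclopentyl groups are not separated, with a 1.2-fold lower number from compound 1 to compound 4 (0.08 log units; within the scatter). The step between compound 2 and compound 3 cannot be read, and the two steps to compound 4 are open on one side: the limit of > 64000 nM in this assay, at which 2 of the 4 values shown sit.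

Still open, on these data alone, is what a hydroxy group or a fluorine in place of methoxy on that aromatic carbon would give.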